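The compounds below may be only part of what the source reports. "The series", "measured", "known", "first", "only" and "open" are said of these compounds alone.

Within the data shown here, in a functional assay on YAC-1 cells (Mus musculus) for activation (a higher number here means that more compound is needed for the effect, a lower number that less compound is needed), compound 1, `C=CCn1c(=O)n(CCCC)c2nc(N)nc(O)c21`, gives 4 uM, the lowest number of the three compounds measured so far. Compound 2, `C=CCn1c(=O)n([C@@H]2O[C@H](CO)[C@H]3OC(=O)O[C@H]32)c2nc(N)nc(O)c21`, gives 20 uM, and compound 3, `C=CCn1c(=S)n(C2OC(COC(C)=O)[C@H]3OC(C)(C)O[C@@H]23)c2nc(N)nc(O)c21`, gives 30 uM. Both numbers are higher than that of compound 1 by more than the scatter of the measurement, while compound 2 and compound 3 lie within the scatter of each other.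

The next structure is compound 4, `C=CCn1c(=O)n(C2C=CC(CO)O2)c2nc(N)nc(O)c21`, and it changes the butyl group of compound 1: a group of 7 heavy atoms (5 carbon, 2 oxygen; one five-membered non-aromatic ring with 1 hetero atom) in place of a group of 4 heavy atoms (4 carbon; no ring), on an aromatic nitrogen. In words, a group of 7 heavy atoms containing a five-membered non-aromatic ring replaces the open butyl chain on an aromatic nitrogen.

Among the measured compounds shown here, no measured pair differs in only one place, so the size of this step has to be judged indirectly. Compound 2 at 20 uM and compound 3 at 30 uM also carry a ring-bearing group on that nitrogen, although they differ from compound 4 in other ways too. That points to a rise beyond the scatter rather than no change. The expected step is a 3.8-fold higher number from compound 1 to compound 4 (0.57 log units; beyond the scatter), which would mean that more compound is needed for the effect. The estimated value for compound 4 is 15 uM, with an expected range from 5 uM to 45 uM.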

Compound 4, concentration for half-maximal effect: 11 uM
Compound 4: the middle estimate sits 1.4-fold (0.13 log units) above what was measured, within the range that was stated.
By their numbers in this assay, from the lowest: compound 1; then compounds 4, 2 and 3 (each within the scatter of the next, the first and the last beyond it).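

Among these compounds, for the first time, a single change on this aromatic nitrogen can be read directly: in this assay, putting the group with the five-membered non-aromatic ring in place of the open butyl chain gives a 2.8-fold higher number from compound 1 to compound 4 (0.44 log units; beyond the scatter). Of these two groups, butyl therefore gives the lower number, so less compound is needed with the open chain. The position still accepts a larger group that brings a ring, a double bond and a hydrogen-bond donor, since compound 4 retains a measurable effect at 11 uM, and no measurement shown here explains the size or direction of this step.

The entering group brings all of these features in one step, so the compounds shown cannot say which of them accounts for the rise in the number. As far as these compounds go, it also remains open how a longer chain such as hexyl, or a chain ending in an amine or a carboxylic acid, would compare with butyl on this nitrogen, and whether any of them would give a lower number.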